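Thiophene for phenyl on the shared core: cytotoxicity outlook

A few compounds are considered here, and "the series" means these few. Any claim that something is new, unique, unknown or untested is made for them only; others in the source may bear on it.

Compound 1, `CCOC(=O)c1sc2nc(-c3cccs3)cc(C(F)(F)F)c2c1N`, in an ADME assay on Huh-7 cells (Homo sapiens) for cytotoxicity, read by MTT assay, with a stated time of 72 h (a lower number here means that less compound is tolerated, a higher number that more compound is tolerated), gives > 20000 nM, a limit of the assay.
Compound 2, `CCOC(=O)c1sc2nc(C3CC3)cc(C(F)(F)F)c2c1N`, in this assay gives > 20000 nM, a limit of the assay.
Compound 3, `CCOC(=O)c1oc2nc(-c3ccccc3)cc(C(F)(F)F)c2c1N`, in this assay gives > 20000 nM, a limit of the assay.

For the measured compounds named here, compound 3 therefore stands where every value so far stands: at the upper limit of the assay, and no measured compound has given a number below it, as the limit of > 20000 nM in this assay, at which 3 of the 3 values shown sit, records. Going by the values given here, the only measured step, a step that the two limits leave unreadable from compound 1 to compound 2, has no readable size, both of its ends being limits.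

Compound 4, `CCOC(=O)c1oc2nc(-c3cccs3)cc(C(F)(F)F)c2c1N`, differs from compound 3 by thiophen-2-yl in place of phenyl on an aromatic carbon. Compound 4 thus carries the same thiophen-2-yl group that compound 1 carries, while keeping the shared core of compound 3. Among the compounds with values here, no measured step bears directly on this change; what the three values show is only that neither aryl substituent tried so far has brought a number within the range of this assay.

Compound 4 is therefore expected to behave like the measured compounds, with no step beyond the scatter, so that a step that the limit leaves unreadable from compound 3 to compound 4 is expected to be flat. For compound 4 the estimate in this assay is 30000 nM, within a range from 15000 nM to 100000 nM, with a limit again the most likely outcome.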

Compound 4, half-maximal cytotoxic concentration: > 20000 nM
Compound 4 ended at the assay's limit (the forecaster's own chance of this, stated with the estimate: 85%); the middle value is on the limit's open side.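

No step can be read between compound 3 and compound 4 in this assay, since the values of both compounds are limits: the limit of > 20000 nM in this assay, at which 4 of the 4 values shown sit. The compounds shown leave open how far any of them lies beyond that limit, and whether any change on the shared core would bring a number within the range of this assay.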